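From compound 3 to compound 4: one group exchanged

The source may hold more compounds than are shown below. What is called first, only, known or untested is meant among the compounds shown, and "the series" means these compounds.

Three compounds that share one core and differ only in the group on the amide carbonyl have been tested so far in an ADME assay on microsomes from liver (Homo sapiens) for metabolic stability, read by LC-MS, with a stated time of 30 min, tested at 1 uM (a lower number here means that less of the compound is left, a higher number that more of the compound is left), as a measure of how well they survive. Compound 1 (`O=C(NCc1ccc(S(=O)(=O)c2ccccc2)cc1)c1nc2ccncc2s1`) gives 68% in this test. Compound 3 (`O=C(NCc1ccc(S(=O)(=O)c2ccccc2)cc1)c1cc2cnccc2[nH]1`) gives 75% in the same test, and the gap to the first is small: a number 7 percentage points higher from compound 1 to compound 3 (within the scatter) in all. Compound 2 (`O=C(NCc1ccc(S(=O)(=O)c2ccccc2)cc1)c1cn2ccnc2cn1`) stands apart with 87% in this test, as the steps of a number 19 percentage points higher from compound 1 to compound 2 (beyond the scatter) and a number 12 percentage points lower from compound 2 to compound 3 (beyond the scatter) show.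

Compound 4 (`O=C(NCc1ccc(S(=O)(=O)c2ccccc2)cc1)c1cnc2nccn2c1`) has not been measured yet. Its structure differs from that of compound 3 by one exchange: a group of 9 heavy atoms (6 carbon, 3 nitrogen; one five-membered aromatic ring with 2 hetero atoms, one six-membered aromatic ring with 2 hetero atoms) in place of a group of 9 heavy atoms (7 carbon, 2 nitrogen; one five-membered aromatic ring with 1 hetero atom, one six-membered aromatic ring with 1 hetero atom), on a carbonyl carbon and nothing else. The entering group has the same atom and ring counts as the group of compound 2, but a different arrangement. Going by the values given here, the closest guide is therefore a number 12 percentage points lower from compound 2 to compound 3 (beyond the scatter) when read backwards, and it is only a single comparison. A rise smaller than that step seems the reasonable expectation, so the expected change is a number 7 percentage points higher from compound 3 to compound 4 (within the scatter) for now. In this assay compound 4 is estimated at 82% with an expected range from 66% to 94% in this test.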

Compound 4, percent of the compound remaining: 60%
Estimate against measurement, compound 4: 22 percentage points above, and the stated range ends above it.
By their numbers in this assay, from the lowest: compounds 4, 1 and 3 (each within the scatter of the next, the first and the last beyond it); then compound 2.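

The pair of compound 2 and compound 4 is the new information: their groups have the same atom and ring counts and differ only in arrangement, yet a number 27 percentage points lower from compound 2 to compound 4 (beyond the scatter) in this assay shows that these counts alone do not set the outcome at this position on the carbonyl carbon. The exchange of the group of compound 3 for the new one gives a number 15 percentage points lower from compound 3 to compound 4 (beyond the scatter), so a group with these counts can lie on either side of compound 3, while a number 8 percentage points lower from compound 1 to compound 4 (within the scatter) leaves compound 1 and compound 4 indistinguishable in this test. Nothing available here accounts for the gap between the two arrangements.

Only two arrangements with these counts are shown, so it remains open which feature of the arrangement goes with the higher number and whether other arrangements would fall near compound 2 or near compound 4. The groups shown are also all of one size, which leaves open how a smaller or larger group on the carbonyl carbon would fare, or one of these groups carrying a methoxy or a nitrile.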